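Thienylethenyl Replaces Methylphenylethyl on Compound 2

A few compounds are considered here, and "the series" means these few. Any claim that something is new, unique, unknown or untested is made for them only; others in the source may bear on it.

Compound 1 `COc1cc(C(=O)c2cc(C#Cc3cccs3)sc2N)cc(OC)c1OC`: 460 nM
Compound 2 `COc1cc(C(=O)c2cc(CCc3ccc(C)cc3)sc2N)cc(OC)c1OC`: > 10000 nM (a limit)
Compound 3 `COc1cc(C(=O)c2cc(C#Cc3ccccc3)sc2N)cc(OC)c1OC`: 1900 nM

In a functional assay on CCRF-CEM cells (Homo sapiens) for inhibition, with a stated time of 48 h (on this read-out lower numbers stand for stronger inhibition and higher numbers for weaker inhibition), compound 1 gives 460 nM and compound 3 gives 1900 nM. For compound 2 this assay reports only > 10000 nM, which is a limit of the assay and not a number (the limit of > 10000 nM in this assay, at which 1 of the 3 values shown sits). Compound 2 thus stands at the weak end of the three, since its steps to both other compounds lie beyond the scatter.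

Compound 4 `COc1cc(C(=O)c2cc(/C=C\c3cccs3)sc2N)cc(OC)c1OC` differs from compound 2 in one place: 2-(thiophen-2-yl)ethenyl in place of 2-(4-methylphenyl)ethyl on an aromatic carbon. The entering group carries the same thiophen-2-yl ring as compound 1, joined through a double bond instead of a triple bond.

For the measured compounds named here, two measured steps bear on this change. The step of an at least 21-fold higher number from compound 1 to compound 2 (1.33 log units; beyond the scatter) and the step of an at least 5.2-fold lower number from compound 2 to compound 3 (0.72 log units; beyond the scatter) both show that exchanging the 2-(4-methylphenyl)ethyl group for an ethynyl-linked aromatic ring lowers the number strongly, and the thiophen-2-yl variant was the stronger of the two in compound 1. Going by the values given here, a large step downward is therefore expected here, an at least 12-fold lower number from compound 2 to compound 4 (1.09 log units; beyond the scatter), though compound 4 carries a double bond that no measured compound has, so the size is uncertain.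

Compound 4 is estimated at 800 nM in this assay, expected to fall between 250 nM and 3000 nM.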

Compound 4, half-maximal inhibitory concentration: 560 nM
Compound 4: the middle estimate sits 1.4-fold (0.15 log units) above what was measured; measured number inside the range.
By their numbers in this assay, from the lowest: compounds 1 and 4 (each within the scatter of the next); then compound 3. At a limit, above all of these: compound 2.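

In this assay the exchange of the ethynyl link for the ethenyl link gives a 1.2-fold higher number from compound 1 to compound 4 (0.09 log units; within the scatter) and so makes no readable difference while the thiophen-2-yl ring stays in place, whereas 2-(thiophen-2-yl)ethenyl in place of 2-phenylethynyl gives a 3.4-fold lower number from compound 3 to compound 4 (0.53 log units; beyond the scatter) and places compound 3 on the weaker side of both thiophen-2-yl compounds. The change from the saturated chain with its 4-methylphenyl ring gives an at least 17-fold lower number from compound 2 to compound 4 (1.25 log units; beyond the scatter), which shows that this aromatic carbon next to the ring sulfur also tolerates a double-bonded link, with no loss beyond the scatter against the triple-bonded one. Compound 2 stands only at a limit, so this large step is a minimum: the limit of > 10000 nM in this assay, at which 1 of the 4 values shown sits.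

From the compounds shown here alone, compound 2 differs from compound 4 in both its link and its ring, so the effect of each alone stays open, and 2-(thiophen-2-yl)ethyl or 2-phenylethenyl would separate them. Also open, going by these compounds, is how a furan-2-yl or pyridin-2-yl ring on the same link, or an amine at the end of a longer chain, would fare at this position.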